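Ring amine in place of open-chain amine: compound 4

The source may report more compounds than this note shows. Statements on the series, on what has been measured and on what is new or still open speak of the compounds shown alone.

Compound 1 `COc1cc(C)c(S(=O)(=O)N(C)CCOCC(=O)N2CCN(CCN(C)C)CC2)c(C)c1` gives 106 nM in an assay on HEK293 cells for displacement of a labelled ligand from B1 bradykinin receptor (Homo sapiens), read by scintillation counting (a higher number here means a weaker inhibitor, a lower number a stronger inhibitor), the highest of the three numbers in hand; compound 2 `COc1cc(C)c(S(=O)(=O)N(C)CCOCC(=O)N2CCC(N3CCN(C(C)C)CC3)CC2)c(C)c1` gives 3.8 nM and compound 3 `COc1cc(C)c(S(=O)(=O)N(C)CCOCC(=O)N2CCC(C(O)CN(C)C)CC2)c(C)c1` gives 30 nM. Compound 4 `COc1cc(C)c(S(=O)(=O)N(C)CCOCC(=O)N2CCN(CC3CCN(C)CC3)CC2)c(C)c1` differs from compound 1 by 1-methylpiperidin-4-yl in place of (dimethylamino)methyl on a saturated chain carbon bound to an amine nitrogen in a ring. For the measured compounds named here, the single measured step, a 7.9-fold higher number from compound 2 to compound 3 (0.90 log units; beyond the scatter), replaced a ring amine by an open-chain amine and the number rose; the move from compound 1 to compound 4 runs the other way, from an open chain to a ring, though the surroundings of the change are not the same. A modest lowering is therefore expected, not a large one. Compound 4 is expected at 40 nM in this assay, within 12 nM to 130 nM, an estimated step of a 2.7-fold lower number from compound 1 to compound 4 (0.42 log units; beyond the scatter).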

Compound 4, inhibition constant: 4.5 nM
The estimate for compound 4 lay 8.9-fold (0.95 log units) above the measured number; measured number outside the range, below it.
By their numbers in this assay, from the lowest: compounds 2 and 4 (each within the scatter of the next); then compound 3; then compound 1.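

The change of (dimethylamino)methyl to 1-methylpiperidin-4-yl on a saturated chain carbon bound to an amine nitrogen in a ring gives a 24-fold lower number from compound 1 to compound 4 (1.37 log units; beyond the scatter) in this assay. This position is therefore highly sensitive to the group it carries, and the ring form is clearly favoured over the open-chain amine in this pair. No measurement in hand explains the step.

The compounds shown do not separate the effect of the ring from that of the added carbon atoms. A longer open chain such as 3-(dimethylamino)propyl, or piperidin-4-yl without the methyl on its nitrogen, would help to address this.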